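Urea Partner Swap: Difluorophenyl Out, Ester Chain In

The compounds below may be only part of what the source reports. "The series", "measured", "known", "first", "only" and "open" are said of these compounds alone.

Two compounds have so far been measured in a functional assay on HEK293 cells for agonist activity at Vasopressin V2 receptor (Homo sapiens), read by a luciferase reporter and cAMP accumulation; on this read-out lower numbers stand for an effect already at smaller amounts and higher numbers for an effect only at larger amounts of compound:
compound 1, `O=C(NCc1ccc(C(=O)N2CCCCc3ccccc32)c(F)c1)Nc1c(F)cccc1F`, gives 180 nM;
compound 2, `Cc1cc(C(=O)N2CCCCc3ccccc32)ccc1CNC(=O)Nc1c(F)cccc1F`, gives 2.1 nM.

Within the data shown here, on these two numbers compound 2 stands lowest; the only other value, that of compound 1, lies far above it, well beyond the usual scatter of this kind of measurement. Compound 3, `Cc1cc(C(=O)N2CCCCc3ccccc32)ccc1CNC(=O)NCC(=O)OC(C)C`, has not yet been tested in this assay. It differs from compound 2 in a single place: (isopropoxycarbonyl)methyl in place of 2,6-difluorophenyl on an amide-type nitrogen. The group that leaves is an aromatic ring with no hydrogen-bond acceptors; the group that enters has no ring and carries two. Among the measured compounds shown here, no pair of measured compounds shows a change of this kind, so nothing measured here says how large its effect will be. Compound 2 already gives 2.1 nM, the lowest number seen, and removing the whole aromatic ring from the urea is expected to move the number upward, by a step of about a 29-fold higher number from compound 2 to compound 3 (1.46 log units; beyond the scatter). Compound 3 is therefore estimated at 60 nM in this assay. The expected range for compound 3 runs from 10 nM to 500 nM.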

Compound 3, half-maximal effective concentration: 140 nM
Estimate against measurement, compound 3: 2.3-fold (0.37 log units) below; measured number inside the range.
By their numbers in this assay, from the lowest: compound 2; then compounds 3 and 1 (each within the scatter of the next).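

In this assay, putting (isopropoxycarbonyl)methyl in place of 2,6-difluorophenyl on the amide-type nitrogen gives a 67-fold higher number from compound 2 to compound 3 (1.82 log units; beyond the scatter), so the number at this position depends strongly on the group attached there. Among these compounds, the step also shows that an aromatic ring on this nitrogen is not required for a measurable effect: compound 3, whose new group has no ring, still gives 140 nM, although the lowest number so far belongs to compound 2, which keeps the ring. Nothing measured here explains why the number rises with this swap.

This single swap changes several things at once, removing a ring and its two fluorine atoms while adding a chain with two hydrogen-bond acceptors, so the compounds shown cannot separate the contribution of each. From the compounds shown here alone, it remains open how the number would respond to a plain phenyl ring without the fluorine atoms, which would test the fluorines alone, or to a carboxylic acid in place of the isopropyl ester, which would test the ester end of the chain.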